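Replacing acetyl with 2-ethoxyethyl in compound 3

The compounds below may be only part of what the source reports. "The series", "measured", "known", "first", "only" and "open" are said of these compounds alone.

Of the compounds shown here, three sharing one core have been tested in a functional assay on MV4-11 cells (Homo sapiens) for antiproliferative activity, read by CellTiter-Glo, with a stated time of 72 h; a lower number here means a stronger inhibitor of growth, a higher number a weaker inhibitor of growth. Compound 1 `COCCNc1cc(-c2csc(NCC3CCOCC3)n2)c(Cl)cn1` gives > 10000 nM in this assay, which is a limit of the assay and not a number. Compound 2 `O=C(Nc1cc(-c2csc(NCC3CCOCC3)n2)c(Cl)cn1)c1ccc(F)cc1` gives 550 nM. Within the data shown here, compound 3 `CC(=O)N[C@H]1CC[C@H](Nc2cc(-c3csc(NCC4CCOCC4)n3)c(Cl)cn2)CC1` gives 3600 nM, the higher of the two actual numbers, beyond the scatter from its only measured neighbour.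

Compound 4 `CCOCCN[C@H]1CC[C@H](Nc2cc(-c3csc(NCC4CCOCC4)n3)c(Cl)cn2)CC1` differs from compound 3 in one group: 2-ethoxyethyl in place of acetyl on an amine nitrogen. In words, 2-ethoxyethyl stands in place of acetyl on an amine nitrogen, so that acetamido becomes (2-ethoxyethyl)amino. Among the measured compounds shown here, no measured step makes this exchange. The three measured steps concern the group on a nitrogen on an aromatic ring: an at least 18-fold lower number from compound 1 to compound 2 (1.25 log units; beyond the scatter), then an at least 2.7-fold lower number from compound 1 to compound 3 (0.44 log units; beyond the scatter), and a 6.5-fold higher number from compound 2 to compound 3 (0.82 log units; beyond the scatter). They show that changing that group, including the introduction of the 4-acetamidocyclohexyl group itself, moves the number by modest to large steps. Compound 2 at 550 nM shows that the shared core can reach far lower numbers than compound 3 does. On this thin evidence, the expected result is a 14-fold lower number from compound 3 to compound 4 (1.16 log units; beyond the scatter), a sizeable step toward stronger growth inhibition. For compound 4 the estimated value is 250 nM, with an expected range of 30 nM to 1500 nM.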

Compound 4, concentration for 50% growth inhibition: 497 nM
Compound 4: the middle estimate sits 2.0-fold (0.30 log units) below what was measured, within the range that was stated.
By their numbers in this assay, from the lowest: compounds 4 and 2 (each within the scatter of the next); then compound 3. At a limit, above all of these: compound 1.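

In this assay, among these compounds, 2-ethoxyethyl in place of acetyl on an amine nitrogen gives a 7.2-fold lower number from compound 3 to compound 4 (0.86 log units; beyond the scatter), the first measured step at this place, as the earlier steps all concerned the group on a nitrogen on an aromatic ring. The change therefore shows that the number responds to the group at this amine nitrogen and not only to the group on the aromatic-ring nitrogen, and it brings compound 4 at 497 nM within the scatter of compound 2 at 550 nM. Nothing on hand bears on why this step has the size it has.

The exchange removes the carbonyl and brings in the longer 2-ethoxyethyl chain in a single step, so the compounds shown do not separate these two parts of the change. On these data alone, whether an unsubstituted amine, a plain ethyl group, a 2-methoxyethyl chain or a longer ether chain on this nitrogen would give a similar number stays open, as does whether a carboxylic acid at the end of such a chain would be tolerated.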